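Benzothiazole-pyrimidine sulfonamides: methyl for fluoro step

The compounds below may be only part of what the source reports. "The series", "measured", "known", "first", "only" and "open" are said of these compounds alone.

Measured so far:
compound 1 `COc1ccc2nc(Nc3ccnc(Nc4ccc(S(N)(=O)=O)cc4)n3)sc2c1`, 3030 nM
compound 2 `NS(=O)(=O)c1ccc(Nc2nccc(Nc3nc4ccc(F)cc4s3)n2)cc1`, 920 nM

Compound 2 gives the lowest number of the two measured in a functional assay on PC-3 cells (Homo sapiens) for antiproliferative activity, read by MTT assay, with a stated time of 48 h; on this read-out higher numbers stand for weaker inhibition and lower numbers for stronger inhibition; its nearest neighbour is compound 1, and the step of a 3.3-fold lower number from compound 1 to compound 2 (0.52 log units; beyond the scatter) lies beyond the scatter. Compound 3 `Cc1ccc2nc(Nc3ccnc(Nc4ccc(S(N)(=O)=O)cc4)n3)sc2c1` has not been measured. It differs from compound 2 by methyl in place of fluoro on an aromatic carbon. Within the data shown here, no measured step swaps a methyl for a fluoro on the shared core; the only step known at this position, a 3.3-fold lower number from compound 1 to compound 2 (0.52 log units; beyond the scatter), swapped methoxy for fluoro and was modest. That step shows the assay responds to a change at this carbon, but it gives no direction for methyl. For compound 3 a number near or somewhat above that of compound 2 is expected in this assay, with a 1.6-fold higher number from compound 2 to compound 3 (0.21 log units; within the scatter) taken as the expected step. The estimate for compound 3 is 1500 nM, within 600 nM to 4000 nM.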

Compound 3, half-maximal inhibitory concentration: 1640 nM
For compound 3 the middle estimate is 1.1-fold (0.04 log units) below the measured one; the range from low to high includes it.
By their numbers in this assay, from the lowest: compounds 2, 3 and 1 (each within the scatter of the next, the first and the last beyond it).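

In this assay methyl in place of fluoro gives a 1.8-fold higher number from compound 2 to compound 3 (0.25 log units; within the scatter) and so does not separate compound 3 from compound 2 at this aromatic carbon. Methyl in place of methoxy gives a 1.8-fold lower number from compound 1 to compound 3 (0.27 log units; within the scatter) and so does not separate compound 3 from compound 1 either, even though a 3.3-fold lower number from compound 1 to compound 2 (0.52 log units; beyond the scatter) sets compound 1 and compound 2 apart; methyl therefore reads as intermediate, resolved from neither of the other groups. No measurement shown here accounts for these numbers.

From the compounds shown here alone, whether an amine, a carboxylic acid or a longer chain at this carbon would shift the number beyond the scatter from compound 2 remains open. Also open, going by these compounds, is how the plain hydrogen compares with these groups on the shared core.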